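Removing a silyl group from an alkyne on two related sulfonamides

A few compounds are considered here, and "the series" means these few. Any claim that something is new, unique, unknown or untested is made for them only; others in the source may bear on it.

Measured compounds:
compound 1, `CC(=O)Nc1nc(-c2cccc(NS(=O)(=O)c3ccc(C#C[Si](C)(C)C)cc3)c2)cs1`: 94.3%
compound 2, `C#Cc1ccc(S(=O)(=O)Nc2cccc(-c3csc(NC(C)=O)n3)c2)cc1`: 59.2%
compound 3, `CC(=O)Nc1nc(-c2cccc(NS(=O)(=O)c3cccc(C#C[Si](C)(C)C)c3)c2)cs1`: 61.6%

In a functional assay on A-375 cells (Homo sapiens) for antiproliferative activity, read by trypan blue exclusion, with a stated time of 48 h, tested at 1 uM (on this read-out lower numbers stand for a stronger effect and higher numbers for a weaker effect at the one concentration tested), compound 1 gives 94.3%. Compound 2 differs from it by a hydrogen atom in place of a group of 4 heavy atoms (3 carbon, 1 silicon; no ring), on a triple-bonded carbon and in this assay compound 2 gives 59.2%, so the step of a number 35.1 percentage points lower from compound 1 to compound 2 (beyond the scatter) is a large one. Compound 3 has the same atoms as compound 1, joined differently; the difference between the two cores is not broken down here. In this assay compound 3 gives 61.6%, which lies within the scatter of compound 2, so no order between compound 2 and compound 3 can be claimed.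

Compound 4, `C#Cc1cccc(S(=O)(=O)Nc2cccc(-c3csc(NC(C)=O)n3)c2)c1`, has not yet been measured. It differs from compound 3 by a hydrogen atom in place of a group of 4 heavy atoms (3 carbon, 1 silicon; no ring), on a triple-bonded carbon, which is the same change as that from compound 1 to compound 2. Within the data shown here, because a number 35.1 percentage points lower from compound 1 to compound 2 (beyond the scatter) was large, the same change is expected to lower the number again, though compound 3 already starts near compound 2, so the step of a number 16.6 percentage points lower from compound 3 to compound 4 (beyond the scatter) is estimated to be smaller than the earlier one, with wide uncertainty since only one example of the change is known. Compound 4 is therefore expected to give about 45% in this assay, in a range from 20% to 70%.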

Compound 4, a percentage reported as activity, at one concentration (the size of the read-out at that concentration, not a potency): 74.3%
Compound 4: the middle estimate sits 29.3 percentage points below what was measured, outside the stated range (above it).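

In this assay, putting a hydrogen atom in place of the silyl group on the triple-bonded carbon gives a number 12.7 percentage points higher from compound 3 to compound 4 (beyond the scatter), which runs against the direction seen on the core of compound 1, and the two steps differ: the same change on two cores in this assay, a number 35.1 percentage points lower (beyond the scatter) from compound 1 to compound 2 and a number 12.7 percentage points higher (beyond the scatter) from compound 3 to compound 4, 47.8 percentage points apart, beyond the scatter of two such steps

In this series, then, neither the size nor the direction of the change carries over from one core to the other, and the result on one core gave no safe guide to the result on the other. The two products of the change also stand apart, with 3-ethynylphenyl in place of 4-ethynylphenyl on the sulfonyl sulfur giving a number 15.1 percentage points higher from compound 2 to compound 4 (beyond the scatter), but this rests on a single pair for each core at the one concentration tested, so it sets no general rule and does not show why the steps diverge.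

The compounds shown leave open how the two cores respond to other groups on the triple-bonded carbon, such as a methyl group or a longer chain. They also leave open whether a nitrile or a carboxylic acid in place of the whole alkyne would follow either core.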